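Longer Sulfur Chain on a Shared Core

The source may hold more compounds than are shown below. What is called first, only, known or untested is meant among the compounds shown, and "the series" means these compounds.

Compound 1 `Nc1nc(O)nc2c1nc(O)n2Cc1ccccc1` carries a hydroxy group on the shared core, and in a functional assay (spleen, spleen) for activation, with Mus musculus as the target (on this read-out higher numbers stand for an effect only at larger amounts of compound and lower numbers for an effect already at smaller amounts), compound 1 gives 0.1 uM. Replacing that hydroxy with propylsulfanyl gives compound 2 `CCCSc1nc(N)c2nc(O)n(Cc3ccccc3)c2n1`, which in this assay gives 0.01 uM, a step of a 10-fold lower number from compound 1 to compound 2 (1.00 log units; beyond the scatter). Putting propyl onto the oxygen instead gives compound 3 `CCCOc1nc(N)c2nc(O)n(Cc3ccccc3)c2n1`, which in this assay gives 0.01 uM, a step of a 10-fold lower number from compound 1 to compound 3 (1.00 log units; beyond the scatter). The swap of sulfur for oxygen, no change at the digits printed from compound 2 to compound 3 (within the scatter), leaves the number unchanged, so compound 3 and compound 2 share the lowest figure of the three, and compound 3 sits far from compound 1.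

Compound 4 `CCCCCSc1nc(N)c2nc(O)n(Cc3ccccc3)c2n1` differs from compound 3 in one place: pentylsulfanyl in place of propoxy on an aromatic carbon. Within the data shown here, no measured step alters chain length. The steps of a 10-fold lower number from compound 1 to compound 2 (1.00 log units; beyond the scatter) and a 10-fold lower number from compound 1 to compound 3 (1.00 log units; beyond the scatter) show that adding a propyl chain at this position lowers the number, and no change at the digits printed from compound 2 to compound 3 (within the scatter) shows sulfur and oxygen give alike results. From the compounds shown here alone, a longer chain is untested, so the expected step of a 1.5-fold higher number from compound 3 to compound 4 (0.18 log units; within the scatter) is small, probably within the scatter. Compound 4 is therefore estimated at 0.015 uM in this assay, with a range from 0.003 uM to 0.08 uM.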

Compound 4, minimum effective concentration: 10 uM
Estimate against measurement, compound 4: 670-fold (2.82 log units) below; the measured number lies above the stated range.
By their numbers in this assay, from the lowest: compounds 2 and 3 (each within the scatter of the next); then compound 1; then compound 4.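

The earlier compounds shown here suggested that a propyl chain on this aromatic carbon helps, but chain length turns out to matter sharply in this assay. Going from propylsulfanyl to pentylsulfanyl gives a 1000-fold higher number from compound 2 to compound 4 (3.00 log units; beyond the scatter) and replacing propoxy gives the same size of step with a 1000-fold higher number from compound 3 to compound 4 (3.00 log units; beyond the scatter), while the comparison with the hydroxy compound, a 100-fold higher number from compound 1 to compound 4 (2.00 log units; beyond the scatter), shows that the longer chain more than cancels the drop seen with the propyl chains. Nothing available explains this reversal.

The compounds shown leave open where between propylsulfanyl and pentylsulfanyl the number starts to climb, which a butylsulfanyl chain would help to place. They also leave open whether pentyloxy, the oxygen counterpart of the longer chain, would behave like compound 4.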